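A few compounds are considered here, and "the series" means these few. Any claim that something is new, unique, unknown or untested is made for them only; others in the source may bear on it.

Going by the values given here, compound 2 `O=S(=O)(NCCNc1nccc(-c2c(-c3cccc(F)c3)nc3sccn23)n1)c1cccc(F)c1` carries a (3-fluorophenyl)sulfonyl group on the amine nitrogen of the shared core, and in a functional assay on A-375 cells (Homo sapiens) for cytotoxicity, read by MTT assay (a lower number here means a stronger inhibitor, a higher number a weaker inhibitor), compound 2 gives 14900 nM, the highest of the two numbers measured so far. Among the compounds with values here, compound 1 `O=C(NCCNc1nccc(-c2c(-c3cccc(F)c3)nc3sccn23)n1)c1c(F)cccc1F` differs from it only at that nitrogen, and in this assay compound 1 gives 2700 nM; the step of a 5.5-fold higher number from compound 1 to compound 2 (0.74 log units; beyond the scatter) is the one measured change that bears on what follows. Compound 3 `O=C(NCCNc1nccc(-c2c(-c3cccc(F)c3)nc3sccn23)n1)c1ccccc1` is the next compound. The change benzoyl in place of (3-fluorophenyl)sulfonyl on an amine nitrogen undoes the sulfonyl-for-carbonyl exchange seen between compound 1 and compound 2, though the ring that enters carries no fluorine. Since the step of a 5.5-fold higher number from compound 1 to compound 2 (0.74 log units; beyond the scatter) raised the number modestly, a step of similar size in the opposite direction is expected, bringing compound 3 back toward compound 1; the estimated step is a 4.3-fold lower number from compound 2 to compound 3 (0.63 log units; beyond the scatter). Compound 3 is therefore expected to give about 3500 nM in this assay, within a range of 1200 nM to 10000 nM.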

Compound 3, half-maximal inhibitory concentration: 5060 nM
Beside the measured number, compound 3's estimate is 1.4-fold (0.16 log units) below it; low and high end bracket the measured number.
By their numbers in this assay, from the lowest: compounds 1 and 3 (each within the scatter of the next); then compound 2.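

At the amine nitrogen, benzoyl in place of (3-fluorophenyl)sulfonyl gives a 2.9-fold lower number from compound 2 to compound 3 (0.47 log units; beyond the scatter) in this assay, showing that a carbonyl link can go with a lower number even when its phenyl ring holds no fluorine. Phenyl in place of 2,6-difluorophenyl on a carbonyl carbon gives a 1.9-fold higher number from compound 1 to compound 3 (0.27 log units; within the scatter) and so leaves no difference that can be read, which the earlier pair could not show. No measurement shown here gives a reason for either step.

The compounds shown leave open whether the sulfonyl link alone accounts for the higher number of compound 2 or whether the fluorine on its ring shares in it. They also leave open how a cyclohexyl group or a pyridine ring on the same carbonyl would read in this assay on this core.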